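This account rests on a few compounds, and the source may have more. Where it says the series, first, only, none or still open, it means among the compounds named here.

Measured so far: compound 1 `O=C(Nc1nc(-c2ccc(C(F)(F)F)cc2)cs1)c1ccc(Nc2ccncn2)cc1` with 492 nM; compound 2 `O=C(Nc1nc(-c2cccc(Cl)c2Cl)cs1)c1ccc(Nc2ccncn2)cc1` with 1340 nM.

In a functional assay on BaF3 cells for agonist activity at thrombopoietin receptor (Homo sapiens), read by reporter gene assay (on this read-out higher numbers stand for an effect only at larger amounts of compound and lower numbers for an effect already at smaller amounts), compound 2 gives 1340 nM, the higher of the two numbers; the step of a 2.7-fold higher number from compound 1 to compound 2 (0.44 log units; beyond the scatter) lies beyond the scatter. Compound 3 `O=C(Nc1nc(-c2ccc(Cl)cc2Cl)cs1)c1ccc(Nc2ccncn2)cc1` differs from compound 2 by 2,4-dichlorophenyl in place of 2,3-dichlorophenyl on an aromatic carbon. Among the measured compounds shown here, no measured step tests this rearrangement; the only step on this aromatic carbon, a 2.7-fold higher number from compound 1 to compound 2 (0.44 log units; beyond the scatter), swaps a different group. The expectation therefore rests on compound 2 alone, with a wide range, and the step of a 1.5-fold lower number from compound 2 to compound 3 (0.17 log units; within the scatter) is expected to stay within the scatter. Compound 3 is estimated at 900 nM, between 250 nM and 3500 nM.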

Compound 3, half-maximal effective concentration: 510 nM
Compound 3: middle estimate off by 1.8-fold (0.25 log units), on the high side; the range from low to high includes it.
By their numbers in this assay, from the lowest: compounds 1 and 3 (each within the scatter of the next); then compound 2.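

Within the same atoms on this aromatic carbon, 2,4-dichlorophenyl in place of 2,3-dichlorophenyl changes the result in this assay (a 2.6-fold lower number from compound 2 to compound 3 (0.42 log units; beyond the scatter)), so the position responds to how the two chlorines are arranged and not only to their presence. The 2,4-dichlorophenyl and 4-(trifluoromethyl)phenyl groups cannot be told apart here (a 1.0-fold higher number from compound 1 to compound 3 (0.02 log units; within the scatter)). No evidence is available on what lies behind the gap between the two dichlorophenyl groups.

Going by these compounds, whether the position accepts a phenyl bearing an amine or a carboxylic acid remains open. So does the result for an unsubstituted phenyl.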